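The source may report more compounds than this note shows. Statements on the series, on what has been measured and on what is new or still open speak of the compounds shown alone.

Among the measured compounds shown here, compound 1 `FC(F)(F)c1cccc(-c2nc3cnc(Nc4ccccn4)cc3[nH]2)c1` gives 21000 nM in a physicochemical assay for solubility, using the shake flask method, measured as kinetic solubility, with a stated time of 20 h, at pH 2 (a higher number here means a more soluble compound, a lower number a less soluble compound), and is the only member of the three measured compounds with a number rather than a limit. Compound 2 `Fc1cnc(Nc2cc3[nH]c(-c4cccc(C(F)(F)F)c4)nc3cn2)c(F)c1` sits at the limit of this assay, < 5000 nM. Compound 3 `NC(=O)c1ccc(Nc2cc3[nH]c(-c4cccc(C(F)(F)F)c4)nc3cn2)nc1` likewise sits at the limit of this assay, < 5000 nM. Compound 4 `FC(F)(F)c1cccc(-c2nc3cnc(Nc4cc(-c5nnn[nH]5)ccn4)cc3[nH]2)c1` differs from compound 1 by 1H-tetrazol-5-yl in place of hydrogen on an aromatic carbon. Both measured steps away from compound 1 fell: an at least 4.2-fold lower number from compound 1 to compound 2 (0.62 log units; beyond the scatter) and an at least 4.2-fold lower number from compound 1 to compound 3 (0.62 log units; beyond the scatter), each ending at the limit of < 5000 nM in this assay, at which 2 of the 3 values shown sit; between the two limits, a step that the two limits leave unreadable from compound 2 to compound 3. A new group on the pyridin-2-yl ring is therefore expected to lower this assay, with a step of a 3.0-fold lower number from compound 1 to compound 4 (0.48 log units; beyond the scatter) expected. The estimate for compound 4 is 7000 nM, within 3000 nM to 20000 nM.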

Compound 4, solubility: < 5000 nM
Compound 4: only a limit was reported (the forecaster's own chance of this, stated with the estimate: 40%); at least 1.4-fold (0.14 log units) between middle value and limit.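

In this assay, 1H-tetrazol-5-yl in place of hydrogen, opposite the ring nitrogen, gives an at least 4.2-fold lower number from compound 1 to compound 4 (0.62 log units; beyond the scatter). The fall seen with the 3,5-difluoropyridin-2-yl and 5-carbamoylpyridin-2-yl changes now extends to a five-membered aromatic ring with 4 hetero atoms at this position, and no substituted compound shown goes against it. The value of compound 4 is a limit, so the full size of its step stays unknown, and it joins the compounds collected there: the limit of < 5000 nM in this assay, at which 3 of the 4 values shown sit.

Steps among compounds 2, 3 and 4 cannot be read. Going by these compounds, whether an amine or a carboxylic acid at this position would stay clear of that limit remains open.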